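Amide to urea on the chloro-trifluoromethyl anilide

The compounds below may be only part of what the source reports. "The series", "measured", "known", "first", "only" and "open" are said of these compounds alone.

compound 1 `COc1cc(-c2nn(-c3cccc(NC(=O)c4cccc(C(F)(F)F)c4)c3)cc2-c2ccncc2)ccc1Cl`: 1670 nM
compound 2 `COc1cc(-c2nn(-c3cccc(NC(=O)Nc4cccc(C(F)(F)F)c4)c3)cc2-c2ccncc2)ccc1Cl`: 900 nM
compound 3 `COc1cc(-c2nn(-c3cccc(NC(=O)c4ccc(Cl)c(C(F)(F)F)c4)c3)cc2-c2ccncc2)ccc1Cl`: 2490 nM

In a functional assay on HCT-116 cells (Homo sapiens) for inhibition, read by sulforhodamine B assay, with a stated time of 48 h (a lower number here means a stronger inhibitor of growth, a higher number a weaker inhibitor of growth), compound 3 gives the highest of the three numbers: its gap to compound 1, a 1.5-fold higher number from compound 1 to compound 3 (0.17 log units; within the scatter), lies within the scatter, while the gap a 2.8-fold higher number from compound 2 to compound 3 (0.44 log units; beyond the scatter) lies beyond it. Compound 4 `COc1cc(-c2nn(-c3cccc(NC(=O)Nc4ccc(Cl)c(C(F)(F)F)c4)c3)cc2-c2ccncc2)ccc1Cl` differs from compound 3 in one place: (4-chloro-3-(trifluoromethyl)phenyl)amino in place of 4-chloro-3-(trifluoromethyl)phenyl on a carbonyl carbon. The same kind of change has been measured once before, as a 1.9-fold lower number from compound 1 to compound 2 (0.27 log units; within the scatter), a step that stayed within the scatter. On that basis the expected step is of similar size and in the same direction, a 1.9-fold lower number from compound 3 to compound 4 (0.28 log units; within the scatter), so no clear separation from compound 3 is anticipated. The estimate for compound 4 is 1300 nM, with a range from 600 nM to 2800 nM.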

Compound 4, concentration for 50% growth inhibition: 1170 nM
Estimate against measurement, compound 4: 1.1-fold (0.05 log units) above; the measured number falls inside the stated range.
By their numbers in this assay, from the lowest: compounds 2, 4, 1 and 3 (each within the scatter of the next, the first and the last beyond it).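

In this assay, the change from amide to urea now passes the scatter when the chloro is present, a 2.1-fold lower number from compound 3 to compound 4 (0.33 log units; beyond the scatter), whereas the same change without the chloro stayed within it. With the urea in place, adding the chloro shifts little, a 1.3-fold higher number from compound 2 to compound 4 (0.11 log units; within the scatter), and the step combining both changes, a 1.4-fold lower number from compound 1 to compound 4 (0.15 log units; within the scatter), also stays within the scatter. The chloro step repeats closely on the amide and urea cores: the same change on two cores in this assay, a 1.5-fold higher number (0.17 log units; within the scatter) from compound 1 to compound 3 and a 1.3-fold higher number (0.11 log units; within the scatter) from compound 2 to compound 4, 1.1-fold (0.06 log units) apart, within the scatter of two such steps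

On these data alone, whether the urea keeps this edge with a bromo or a nitrile in place of the chloro remains open. So does the effect of a methyl on the new urea nitrogen.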